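A few compounds are considered here, and "the series" means these few. Any claim that something is new, unique, unknown or untested is made for them only; others in the source may bear on it.

Measured so far in a functional assay on SK-MEL-28 cells (Homo sapiens) for inhibition, read by colorimetric assay and MTT assay, with a stated time of 72 h; on this read-out higher numbers stand for weaker inhibition and lower numbers for stronger inhibition:
compound 1 (`C=CCCCCOc1ccccc1-c1cnc(OCCCCC=C)n1C`) gives 5000 nM
compound 2 (`C=CCCCCOc1ncc(-c2ccccc2OC)n1C`) gives 13000 nM

Compound 1 has the lower of these two numbers, so it is the stronger inhibitor of the pair. Compound 3 (`C=CCCCCOc1ccccc1-c1cnc(S(=O)(=O)c2ccccc2)n1C`) has not yet been measured. It differs from compound 1 by phenylsulfonyl in place of (hex-5-en-1-yl)oxy on an aromatic carbon. Among the measured compounds shown here, the only measured step (a 2.6-fold higher number from compound 1 to compound 2 (0.41 log units; beyond the scatter)) is modest, but it changes a different chain, and compound 2 keeps the (hex-5-en-1-yl)oxy that compound 3 loses. That step gives a rough size and no direction for this swap. No clear shift beyond the scatter is therefore expected in this assay, though the uncertainty is wide. The estimated step (a 1.3-fold lower number from compound 1 to compound 3 (0.10 log units; within the scatter)) has no firm direction. For compound 3 the expected value is 4000 nM with an estimated range from 800 nM to 20000 nM on this read-out.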

Compound 3, half-maximal inhibitory concentration: 38000 nM
Compound 3: the middle estimate sits 9.5-fold (0.98 log units) below what was measured; the measured number lies above the stated range.
By their numbers in this assay, from the lowest: compound 1; then compound 2; then compound 3.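

In this assay this carbon of the core, between two ring nitrogen atoms, proves sensitive to what it carries: phenylsulfonyl in place of (hex-5-en-1-yl)oxy gives a 7.6-fold higher number from compound 1 to compound 3 (0.88 log units; beyond the scatter) and so weaker inhibition. Among the compounds shown here, until now only the chain on the other side of compound 1 had been changed, so this is the first sign that the group at this carbon matters too. Nothing here explains the loss of activity.

The swap removes a chain with no ring and brings in a sulfonyl unit and an aromatic ring together, so these compounds cannot show which part of the change matters. A plain phenyl group, a benzyl group or an amine on this carbon would show how the activity changes when the ring and the sulfonyl unit are separated.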